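The source may hold more compounds than are shown below. What is called first, only, known or untested is meant among the compounds shown, and "the series" means these compounds.

Of the compounds shown here, two of a shared core have been measured so far in an assay on isolated protein for binding affinity to leukotriene B4 receptor 1 (Homo sapiens), tested at 1 uM; a lower number here means less inhibition, a higher number more inhibition at the concentration tested (going by the name of the read-out). Compound 1, `C=CCc1cc(C(C)=O)c(O)cc1OCCCC#N`, gives 6% in this assay. Compound 2, `CCc1cc(C(C)=O)c(O)cc1OCCCC(C)(C)C(=O)O`, gives 43% in this assay, which is the highest of the two numbers, standing a long way above compound 1 by a margin beyond the usual scatter. Going by the values given here, these two compounds differ in more than one place, so the two values say only that compound 2 binds more strongly under these conditions, not which part of the structure carries the gain.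

Compound 3, `CCc1cc(C(C)=O)c(O)cc1OCCCCCC[S+](C)[O-]`, has not yet been measured in this assay. It arises from compound 2 by the change (a group of 6 heavy atoms (4 carbon, 1 oxygen, 1 sulfur; no ring) in place of a group of 6 heavy atoms (4 carbon, 2 oxygen; no ring), on a saturated chain carbon, three bonds along the chain from an oxygen on an aromatic ring). The group that leaves carries the only hydrogen-bond donor of that part of the molecule, and the group that enters carries none.

Among the compounds with values here, no measured pair in this set reports such a change, so the size of the step can only be estimated. The expectation is a decrease in this assay, beyond the scatter, of about a number 23 percentage points lower from compound 2 to compound 3 (beyond the scatter). Compound 3 is therefore estimated to give 20% in this assay, within a range from 2% to 45%.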

Compound 3, a percentage reported as inhibition, at one concentration (the size of the read-out at that concentration, not a potency): 50%
Estimate against measurement, compound 3: 30 percentage points below; measured number outside the range, above it.
By their numbers in this assay, from the lowest: compound 1; then compounds 2 and 3 (each within the scatter of the next).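

In this assay, placing the sulfur-bearing group in place of 1-carboxy-1-methylethyl, on a saturated chain carbon, three bonds along the chain from an oxygen on an aromatic ring, gives a number 7 percentage points higher from compound 2 to compound 3 (within the scatter), so this assay does not tell the two groups apart at this position. Going by these compounds alone, this is the first comparison in the set in which two compounds differ in one place only, whereas the gap between compound 1 and compound 2 could not be assigned to any single part of the structure. It also shows that, on this core and at this place, the carboxylic acid and its hydrogen-bond donor can give way to a group with no such donor without a step beyond the scatter. No independent measurement bears on why these two groups read alike.

As far as these compounds go, whether a simple amine, a sulfone or a longer chain at the same place would also fall within the scatter of compound 2 stays open. Also open, from the compounds shown here alone, is how much of the gap between compound 1 and compound 2 belongs to the nitrile and how much to the other place in which they differ, since a nitrile on the ethyl-bearing core would be needed to separate the two.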